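A few compounds are considered here, and "the series" means these few. Any claim that something is new, unique, unknown or untested is made for them only; others in the source may bear on it.

Compound 1 `CCCc1nc(-c2ccccc2)c(CNCCCN2CCN(c3ccc(OC)cc3)CC2)o1` was examined in an assay on HEK293 cells for inhibition of Voltage-dependent T-type calcium channel subunit alpha-1G (Homo sapiens), read by fluorescence, tested at 10 uM (on this read-out higher numbers stand for more inhibition at the one concentration tested (going by the name of the read-out) and lower numbers for less inhibition), and gave 42.1%. Compound 2 `CCCc1nc(-c2ccccc2)c(CNCCCN2CCN(c3ccc(C(F)(F)F)cc3)CC2)o1` shares the core of compound 1 and differs from it in one place: trifluoromethyl in place of methoxy on an aromatic carbon. In this assay compound 2 gave 51.6%. The change made a number 9.5 percentage points higher from compound 1 to compound 2 (within the scatter), so the two numbers cannot be told apart with confidence.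

Compound 3 `CCCc1nc(-c2ccccc2)c(CNCCN2CCN(c3ccc(OC)cc3)CC2)o1` carries the methoxy-bearing ring on a different core; how the core of compound 3 differs from the core of compound 1 is not broken down here. In this assay compound 3 gave 51.5%, a number that sits within the scatter of both compound 1 and compound 2, so no order among the three can be read from them.

Compound 4 `CCCc1nc(-c2ccccc2)c(CNCCN2CCN(c3ccc(C(F)(F)F)cc3)CC2)o1` is to compound 3 what compound 2 is to compound 1: trifluoromethyl in place of methoxy on an aromatic carbon. The place is described in the same words for both pairs, so this is the same change made on a second core. Because the earlier change gave a number 9.5 percentage points higher from compound 1 to compound 2 (within the scatter), the step from compound 3 to compound 4 is expected to be of similar size, a number 6.5 percentage points higher from compound 3 to compound 4 (within the scatter), though it rests on a single earlier pair whose step itself lay within the scatter. Compound 4 is therefore estimated to give 58% in this assay, with a range from 45% to 72%.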

Compound 4, a percentage reported as inhibition, at one concentration (the size of the read-out at that concentration, not a potency): 58.7%
Beside the measured number, compound 4's estimate is 0.7 percentage points below it; measured number inside the range.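

On the core of compound 3, trifluoromethyl in place of methoxy on the aromatic carbon, para to a large group, gave a number 7.2 percentage points higher from compound 3 to compound 4 (within the scatter) in this assay. Set beside the same change on the core of compound 1, the new step agrees in size with the earlier one: the same change on two cores in this assay, a number 9.5 percentage points higher (within the scatter) from compound 1 to compound 2 and a number 7.2 percentage points higher (within the scatter) from compound 3 to compound 4, 2.3 percentage points apart, within the scatter of two such steps. This fits a change that carries from one of these two cores to the other, but each step on its own lies within the scatter, so the data do not establish that the change has a real effect on either core, and two pairs cannot speak for any further core in the series.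

The compounds shown leave open how other groups on that aromatic carbon, such as a nitrile, a chlorine or a carboxylic acid, would read in this assay, as only methoxy and trifluoromethyl appear there. They also leave open whether a longer chain than those in compound 1 and compound 3 would fit the same picture, and, as each number comes from a single concentration, they say nothing about potency.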